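The source may hold more compounds than are shown below. What is called first, only, known or untested is meant among the compounds shown, and "the series" means these compounds.

Measured compounds:
compound 1 `O/N=C(/Nc1cccc(Br)c1)c1ccc2occc2c1` — 1100 nM
compound 2 `O/N=C(/Nc1ccc(F)c(Br)c1)c1ccc2occc2c1` — 2600 nM
compound 3 `O=C(NCC1CCCCC1)c1cccc(N/C(=N/O)c2ccc3occc3c2)c1` — reported only as a limit, > 30000 nM

All three share a core and were tested in an assay on tissue (HeLa cells) for inhibition of Indoleamine 2,3-dioxygenase 1 (Homo sapiens), read by spectrophotometry; a higher number here means a weaker inhibitor, a lower number a stronger inhibitor. Compound 1 gives the lowest of the two numbers that were actually measured. Within the data shown here, its nearest neighbour is compound 2, and that pair is the only single-point change with a number on both sides: a 2.4-fold higher number from compound 1 to compound 2 (0.37 log units; beyond the scatter). Among the measured compounds shown here, for compound 3 the result is a limit of the assay and not a number; it is the one value sitting at the limit of > 30000 nM in this assay, at which 1 of the 3 values shown sits. For the measured compounds named here, compound 3 differs from compound 1 in more than the single exchange described below, so its result only shows that a large group on that ring is tolerated poorly.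

Compound 4 `O/N=C(/Nc1cccc(Oc2ccccc2)c1)c1ccc2occc2c1` is the unmeasured one. It differs from compound 1 by phenoxy in place of bromo on an aromatic carbon. Going by the values given here, no measured step changes exactly this position in this way. The fluoro step gives a modest weakening from a small change, and the bulky compound 3 gives only a limit. The phenoxy group is larger than bromo but far smaller than what compound 3 carries, so a weakening of intermediate size is expected: a 3.6-fold higher number from compound 1 to compound 4 (0.56 log units; beyond the scatter). Compound 4 is therefore estimated at 4000 nM, with a likely range from 1200 nM to 15000 nM.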

Compound 4, half-maximal inhibitory concentration: > 30000 nM
Compound 4: a limit, no number (the forecaster's own chance of this, stated with the estimate: 15%); middle value at least 7.5-fold (0.87 log units) away from the limit.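

Putting phenoxy in place of bromo at this position costs far more than the fluoro step on the same ring suggested: the exchange gives an at least 27-fold higher number from compound 1 to compound 4 (1.43 log units; beyond the scatter). In this assay, as far as these compounds go, compound 4 gives > 30000 nM, which is a limit of the assay and not a number, so the true size of the loss stays unknown. Until now only the much larger group of compound 3 had reached this limit, but a group of 7 heavy atoms with a single ring is now enough to reach it, so activity at this position is lost with far less added bulk than compound 3 carries: the limit of > 30000 nM in this assay, at which 2 of the 4 values shown sit.

The compounds shown leave open where, between bromo and phenoxy, the tolerance of this position ends; a methoxy group, an amine or an ethyl chain in place of bromo could show whether anything other than a halogen keeps the number close to that of compound 1, 1100 nM. They also leave open whether the loss comes from the ring or from the oxygen linking it, which a directly attached phenyl group would help to separate.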